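The compounds below may be only part of what the source reports. "The series", "measured", "known", "first", "only" and "open" are said of these compounds alone.

Compound 1 `CCOC(=O)C1=Cc2ccccc2OC1(OCc1cc(-c2ccc3ccccc3c2)no1)C(F)(F)F` gives 71800 nM in a functional assay on DU-145 cells (Homo sapiens) for inhibition, read by MTT assay, with a stated time of 24 h; a lower number here means a stronger inhibitor, a higher number a weaker inhibitor. Among the two numbers recorded, compound 2 `O=C(O)C1=Cc2ccccc2OC1(OCc1cc(-c2ccc3ccccc3c2)no1)C(F)(F)F` stands at 141000 nM, separated from compound 1 only by a 2.0-fold higher number from compound 1 to compound 2 (0.29 log units; within the scatter). For compound 3 `CCOC(=O)C1=Cc2ccccc2OC1(OCc1cn(CC(=O)Nc2cccc(F)c2)nn1)C(F)(F)F` this assay reports only a limit, > 150000 nM. Compound 4 `O=C(O)C1=Cc2ccccc2OC1(OCc1cc(-c2cccc(C(F)(F)F)c2)no1)C(F)(F)F` differs from compound 2 by 3-(trifluoromethyl)phenyl in place of naphthalen-2-yl on an aromatic carbon. Within the data shown here, no measured step touches this change: the single step recorded, a 2.0-fold higher number from compound 1 to compound 2 (0.29 log units; within the scatter), concerns the ester and says nothing about the aryl group on the five-membered ring. The step of a 1.1-fold higher number from compound 2 to compound 4 (0.03 log units; within the scatter) is therefore expected to be small, with wide uncertainty. Compound 4 is expected at 150000 nM, from 50000 nM to 400000 nM. A limit rather than a number is quite possible for compound 4, because the limit of > 150000 nM in this assay, at which 1 of the 3 values shown sits, already holds one of the three values.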

Compound 4, half-maximal inhibitory concentration: 155000 nM
The estimate for compound 4 lay 1.0-fold (0.01 log units) below the measured number; the measured number falls inside the stated range.
By their numbers in this assay, from the lowest: compounds 1, 2 and 4 (each within the scatter of the next, the first and the last beyond it).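

Replacing naphthalen-2-yl with 3-(trifluoromethyl)phenyl on this aromatic carbon, next to the ring nitrogen, gives a 1.1-fold higher number from compound 2 to compound 4 (0.04 log units; within the scatter) in this assay. Among these compounds, the one earlier step concerned the ester, so this pair gives the first reading at the aryl position, and here one six-membered aromatic ring and two do not separate. Compound 3 carries a limit, not a number: the limit of > 150000 nM in this assay, at which 1 of the 4 values shown sits.

From the compounds shown here alone, whether an amine or a longer chain at this carbon would give a step beyond the scatter stays open. So does whether the same aryl change would read alike with the ethyl ester in place of the carboxylic acid.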